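Chloro for methoxy on a level pair

A few compounds are considered here, and "the series" means these few. Any claim that something is new, unique, unknown or untested is made for them only; others in the source may bear on it.

compound 1 `COc1ccc(/C=C/C(=O)/C=C/c2nc3ccccc3n2C)cc1O`: 3600 nM
compound 2 `COc1ccc2c(c1)nc(/C=C/C(=O)/C=C/c1ccc(OC)c(O)c1)n2C`: 3700 nM

Within the data shown here, in a functional assay on MCF7 cells (Homo sapiens) for cytotoxicity, read by MTT assay, with a stated time of 48 h (a lower number here means a stronger inhibitor, a higher number a weaker inhibitor), compound 2 stands level with the only other measured compound, and the two cannot be told apart: the record shows a 1.0-fold higher number from compound 1 to compound 2 (0.01 log units; within the scatter). Compound 3 `COc1ccc(/C=C/C(=O)/C=C/c2nc3cc(Cl)ccc3n2C)cc1O` differs from compound 2 in one place: chloro in place of methoxy on an aromatic carbon. Among the measured compounds shown here, one measured step bears on this change, the methoxy in place of hydrogen on an aromatic carbon that gave a 1.0-fold higher number from compound 1 to compound 2 (0.01 log units; within the scatter). For the measured compounds named here, that step stays within the scatter, but no compound with chloro has yet been measured, so this evidence is thin. No step beyond the scatter is therefore expected in this assay. The expected step is a 1.1-fold lower number from compound 2 to compound 3 (0.02 log units; within the scatter). For compound 3 the estimated value is 3500 nM, with an expected range of 1500 nM to 8000 nM.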

Compound 3, half-maximal inhibitory concentration: 3500 nM
Compound 3: the middle estimate sits on the measured number at the digits printed; low and high end bracket the measured number.
By their numbers in this assay, from the lowest: compounds 3, 1 and 2 (each within the scatter of the next).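

In this assay, chloro in place of methoxy gives a 1.1-fold lower number from compound 2 to compound 3 (0.02 log units; within the scatter), and chloro in place of hydrogen gives a 1.0-fold lower number from compound 1 to compound 3 (0.01 log units; within the scatter), so both steps lie within the scatter. This aromatic carbon has now carried hydrogen, methoxy and chloro without the three compounds being told apart, even though methoxy and chloro differ in heavy atoms and in hydrogen-bond acceptors as counted. Nothing independent of these cell numbers accounts for how level they are.

The compounds shown leave open whether an amine, a carboxylic acid or a longer alkoxy chain on this carbon would give a step beyond the scatter. They also leave open how the number would respond to a change elsewhere on the shared core, such as replacing the hydroxy group with an amine.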